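The source may report more compounds than this note shows. Statements on the series, on what has been measured and on what is new or still open speak of the compounds shown alone.

Measured so far in a functional assay on PC-3 cells (Homo sapiens) for inhibition; on this read-out higher numbers stand for weaker inhibition and lower numbers for stronger inhibition:
- compound 1 `Cc1c(C(=O)N/N=C\c2ccc(O)cc2)oc2cccc(O)c12`: 21700 nM
- compound 2 `Cc1c(C(=O)N/N=C\c2cccc(F)c2O)oc2cccc(O)c12`: 12700 nM
- compound 3 `Cc1c(C(=O)N/N=C\c2ccc(F)cc2)oc2cccc(O)c12`: a limit of the assay, >= 40000 nM

Compound 2 has the lowest of the two numbers given. The nearest is compound 1, and the step of a 1.7-fold lower number from compound 1 to compound 2 (0.23 log units; within the scatter) sits within the scatter, so the two cannot be ordered. Compound 3 gives only a limit, and the limit of >= 40000 nM in this assay, at which 1 of the 3 values shown sits, marks where that limit lies. Among the compounds with values here, the step of an at least 3.1-fold higher number from compound 2 to compound 3 (0.49 log units; beyond the scatter) is the one step that goes beyond the scatter, and an at least 1.8-fold higher number from compound 1 to compound 3 (0.26 log units; that floor lies within the scatter) sets a floor that still lies within it.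

Compound 4 `Cc1c(C(=O)N/N=C\c2cccc(Br)c2O)oc2cccc(O)c12` is not yet measured. It differs from compound 2 as bromo in place of fluoro on an aromatic carbon. Within the data shown here, no measured step swaps one halogen for another; the steps that bear on it are a 1.7-fold lower number from compound 1 to compound 2 (0.23 log units; within the scatter), which brought in fluoro together with the 2-hydroxy group without a change beyond the scatter, and an at least 3.1-fold higher number from compound 2 to compound 3 (0.49 log units; beyond the scatter), which removed both. Keeping the 2-hydroxy group and changing only fluoro to bromo gives no ground to expect a step beyond the scatter in this assay, in either direction.

Compound 4 is therefore estimated at 10000 nM in this assay, between 4000 nM and 25000 nM. The expected step of a 1.3-fold lower number from compound 2 to compound 4 (0.10 log units; within the scatter) stays within the scatter.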

Compound 4, half-maximal inhibitory concentration: 16600 nM
Estimate against measurement, compound 4: 1.7-fold (0.22 log units) below; the measured number falls inside the stated range.
By their numbers in this assay, from the lowest: compounds 2, 4 and 1 (each within the scatter of the next). At a limit, above all of these: compound 3.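

The step of a 1.3-fold higher number from compound 2 to compound 4 (0.12 log units; within the scatter) in this assay is the only one shown that changes the halogen alone, on an aromatic carbon ortho to a hydroxy group, and it stays within the scatter, so fluoro and bromo cannot be ordered at this place. The step of a 1.3-fold lower number from compound 1 to compound 4 (0.12 log units; within the scatter) also stays within the scatter, so the 3-bromo-2-hydroxyphenyl and 4-hydroxyphenyl groups cannot be ordered either. The step of an at least 2.4-fold lower number from compound 3 to compound 4 (0.38 log units; beyond the scatter) goes beyond the scatter, which gives a second 2-hydroxyphenyl compound set apart from the 4-fluorophenyl compound. The value of compound 3 remains a limit of the assay: the limit of >= 40000 nM in this assay, at which 1 of the 4 values shown sits.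

Whether an amine or a carboxylic acid on this aromatic carbon would give a step beyond the scatter remains open, as fluoro and bromo are the only groups shown there. Also open is how the gap to compound 3 divides between the hydroxy group and the place of the halogen, as these two change together in every step shown.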